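A few compounds are considered here, and "the series" means these few. Any claim that something is new, unique, unknown or untested is made for them only; others in the source may bear on it.

In a functional assay on T-24 cells (Homo sapiens) for antiproliferative activity, read by MTT assay, with a stated time of 48 h (a higher number here means a weaker inhibitor, a lower number a stronger inhibitor), three compounds built on one shared core have been measured. Compound 1 `O=C(Nc1cccc(CNc2nccnc2Cl)c1)Nc1ccccc1Cl` gives 6680 nM, and compound 2 `O=C(Nc1ccc(Cl)cc1)Nc1cccc(CNc2nccnc2Cl)c1` gives 5470 nM; the step of a 1.2-fold lower number from compound 1 to compound 2 (0.09 log units; within the scatter) lies within the scatter, so these two cannot be told apart. Compound 3 `Cc1ccccc1NC(=O)Nc1cccc(CNc2nccnc2Cl)c1` gives 13600 nM, the highest of the three numbers, and its steps from the other two, a 2.0-fold higher number from compound 1 to compound 3 (0.31 log units; beyond the scatter) and a 2.5-fold higher number from compound 2 to compound 3 (0.40 log units; beyond the scatter), both lie beyond the scatter, so compound 3 is the weakest inhibitor among those measured.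

Compound 4 `O=C(Nc1cccc(CNc2nccnc2Cl)c1)Nc1ccc(F)c(Cl)c1` has not yet been measured. It differs from compound 3 in one place: 3-chloro-4-fluorophenyl in place of 2-methylphenyl on an amide-type nitrogen. The measured steps that bear on this are the two that lead into compound 3, where chloro became methyl, or 4-chlorophenyl became 2-methylphenyl, and the number rose modestly each time. Running the other way, toward a phenyl carrying chloro and fluoro, a modest fall is expected. The estimate for compound 4 in this assay is 5500 nM, with a range from 2500 nM to 12000 nM, which is expected to amount to a step of a 2.5-fold lower number from compound 3 to compound 4 (0.39 log units; beyond the scatter).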

Compound 4, half-maximal inhibitory concentration: 4990 nM
Beside the measured number, compound 4's estimate is 1.1-fold (0.04 log units) above it; the measured number falls inside the stated range.
By their numbers in this assay, from the lowest: compounds 4, 2 and 1 (each within the scatter of the next); then compound 3.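

In this assay, replacing 2-methylphenyl with 3-chloro-4-fluorophenyl on the amide-type nitrogen gives a 2.7-fold lower number from compound 3 to compound 4 (0.44 log units; beyond the scatter), so a ring carrying two halogens separates clearly from the methyl-bearing ring. The same ring cannot be told apart from either ring with one chlorine, as shown by a 1.1-fold lower number from compound 2 to compound 4 (0.04 log units; within the scatter) and by a 1.3-fold lower number from compound 1 to compound 4 (0.13 log units; within the scatter); among these four compounds, the three with halogen-bearing rings form one group, and compound 3, with its methyl-bearing ring, stands apart. Nothing available explains these differences.

The compounds shown leave open how a plain phenyl ring, or a ring bearing an amine or a carboxylic acid, would compare at this nitrogen. They also leave open whether a longer alkyl chain could take the place of the ring there.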